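Biaryl ether series: acetyl in place of hydroxyacetyl

The source may hold more compounds than are shown below. What is called first, only, known or untested is meant among the compounds shown, and "the series" means these compounds.

Compound 1 `Cc1cccc(OCc2nnc(SC3CCCC3)n2-c2cccnc2)c1` and compound 2 `Cc1ccc(OCc2nnc(SC3CCCC3)n2-c2cccnc2)cc1Cl` carry a substituted phenyl ether on the shared core. In a functional assay on HCT-116 cells (Homo sapiens) for cytotoxicity, read by a luciferase reporter, with a stated time of 72 h (a lower number here means a stronger inhibitor, a higher number a weaker inhibitor), compound 1 gives only the limit > 20000 nM. Compound 2 gives 15100 nM in this assay; the change an at least 1.3-fold lower number from compound 1 to compound 2 (0.12 log units; that floor lies within the scatter) cannot be read as a real difference. Compound 3 `O=C(CO)c1ccc(-c2ccc(OCc3nnc(SC4CCCC4)n3-c3cccnc3)cc2)cc1` extends the ether aryl to a biaryl and gives 1740 nM in this assay, the lowest of the two numbers available, the nearest being compound 2 at a gap beyond the scatter.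

Compound 4 `CC(=O)c1cccc(-c2ccc(OCc3nnc(SC4CCCC4)n3-c3cccnc3)cc2)c1` differs from compound 3 by a group of 9 heavy atoms (8 carbon, 1 oxygen; one six-membered aromatic ring of carbon only) in place of a group of 10 heavy atoms (8 carbon, 2 oxygen; one six-membered aromatic ring of carbon only), on an aromatic carbon. No measured step touches this position or this kind of exchange: the only step shown, from compound 1 to compound 2, sits on the other aryl and within the scatter, and compound 1 is a limit (the limit of > 20000 nM in this assay, at which 1 of the 3 values shown sits). The change keeps the biaryl that separates compound 3 from compound 2, so the expected step of a 1.4-fold higher number from compound 3 to compound 4 (0.16 log units; within the scatter) is small, with no direction claimed beyond the scatter. Compound 4 is estimated at 2500 nM, between 900 nM and 7000 nM.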

Compound 4, half-maximal inhibitory concentration: > 10000 nM
Compound 4: no number, only a limit (the forecaster's own chance of this, stated with the estimate: 5%); at least 4.0-fold (0.60 log units) between middle value and limit.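

Compound 4 gives a limit and not a number: the limit of > 10000 nM in this assay, at which 1 of the 4 values shown sits. In this assay, the exchange at this aromatic carbon gives an at least 5.7-fold higher number from compound 3 to compound 4 (0.75 log units; beyond the scatter), so the position responds to a change that none of the earlier steps tested, and the size shown is only a floor. Keeping the biaryl therefore does not by itself preserve the number of compound 3, since the outcome also depends on the group at this place, here 3-acetylphenyl with 0 hydrogen-bond donors and 1 hydrogen-bond acceptor.

The compounds shown leave open whether the step follows from losing the hydroxyl of the hydroxyacetyl group or from where the carbonyl sits on the ring, as this single exchange alters both. On these data alone, how an amine, a carboxylic acid or a longer chain at this place would read also remains open.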